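A few compounds are considered here, and "the series" means these few. Any claim that something is new, unique, unknown or untested is made for them only; others in the source may bear on it.

Measured so far:
Compound 1 `COc1ccc(SCc2ccc(/C=C/C(=O)Nc3ccccc3N)cc2)cc1OC`: 21.9%
Compound 2 `COc1ccc(SCc2ccc(C(=O)Nc3ccccc3N)cc2)cc1`: 79.7%

In a functional assay on HeLa cells (Homo sapiens) for inhibition, read by CCK-8 assay, with a stated time of 72 h, tested at 8 uM (on this read-out lower numbers stand for less inhibition of growth and higher numbers for more inhibition of growth at the one concentration tested), compound 1 gives the lowest of the two numbers; compound 2 stands far higher, a gap beyond the scatter. Compound 3 `Nc1ccccc1NC(=O)/C=C/c1ccc(CSc2ccc(C(F)(F)F)cn2)cc1` has not been measured. It differs from compound 1 by one change: 5-(trifluoromethyl)pyridin-2-yl in place of 3,4-dimethoxyphenyl on a sulfur. For the measured compounds named here, no two measured compounds are related by a single change, so the effect of this one cannot be read from the data. Compound 3 is expected to lie a little higher than compound 1, a step of a number 13.1 percentage points higher from compound 1 to compound 3 (beyond the scatter) that may still fall within the scatter. Compound 3 is estimated at 35%, with a range from 10% to 65%.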

Compound 3, percent growth inhibition at one concentration: 6.82%
Compound 3: the middle estimate sits 28.2 percentage points above what was measured, and the stated range ends above it.
By their numbers in this assay, from the lowest: compound 3; then compound 1; then compound 2.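

In this assay, for the compounds shown here, 5-(trifluoromethyl)pyridin-2-yl in place of 3,4-dimethoxyphenyl on a sulfur gives a step of a number 15.1 percentage points lower from compound 1 to compound 3 (beyond the scatter), the first single change that can be read here. Growth inhibition at this position therefore depends on the group on the sulfur, even though both groups have the same heavy-atom count. Nothing available explains this drop.

As far as these compounds go, it remains open whether the trifluoromethyl group or the ring nitrogen accounts for the step, as the two enter together. From the compounds shown here alone, how an unsubstituted pyridin-2-yl, or a phenyl bearing a carboxylic acid, would behave on the sulfur also remains open.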